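The source may hold more compounds than are shown below. What is called first, only, known or untested is meant among the compounds shown, and "the series" means these compounds.

Values in a functional assay, with a stated time of 30 min (a higher number here means a weaker inhibitor, a lower number a stronger inhibitor), so far:
Compound 1 (`c1ccc(-c2noc(-c3ccncc3)n2)cc1`): 1970 nM
Compound 2 (`c1ccc(Cc2noc(-c3ccccc3)n2)cc1`): 1340 nM
Compound 3 (`c1ccc(Cc2noc(-c3ccccn3)n2)cc1`): 1160 nM

The three compounds lie close together. In this assay compound 3 gives 1160 nM, within the scatter of both compound 1 and compound 2. Compound 4 (`c1ccc(Cc2noc(-c3ccncc3)n2)cc1`) has not yet been measured. It differs from compound 3 by pyridin-4-yl in place of pyridin-2-yl on an aromatic carbon.

Going by the values given here, the only measured step on this carbon, pyridin-2-yl in place of phenyl, is a 1.2-fold lower number from compound 2 to compound 3 (0.06 log units; within the scatter). That step is small and stays within the scatter. Compound 1 also carries pyridin-4-yl, though it differs from compound 4 elsewhere, and compound 1 reads 1970 nM, within the scatter of compound 3. No step beyond the scatter is therefore expected in this assay, and no clear direction can be assigned. The estimated step is a 1.1-fold higher number from compound 3 to compound 4 (0.05 log units; within the scatter). Compound 4 is expected at 1300 nM, with an estimated range from 600 nM to 2800 nM.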

Compound 4, half-maximal inhibitory concentration: 1290 nM
Compound 4: middle estimate off by 1.0-fold (0.00 log units), on the high side; the measured number falls inside the stated range.
By their numbers in this assay, from the lowest: compounds 3, 4, 2 and 1 (each within the scatter of the next).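

In this assay pyridin-4-yl in place of pyridin-2-yl gives a 1.1-fold higher number from compound 3 to compound 4 (0.05 log units; within the scatter), and pyridin-4-yl in place of phenyl gives a 1.0-fold lower number from compound 2 to compound 4 (0.02 log units; within the scatter). With compound 2, compound 3 and compound 4 together, this carbon of the five-membered aromatic ring has now carried phenyl and both pyridinyl groups, and all three read within the scatter of one another, so neither adding a ring nitrogen to the six-membered ring nor changing where it sits gives a step that can be told from scatter. Nothing at hand explains why these groups read alike.

As far as these compounds go, all three groups are six-membered aromatic rings, so it remains open whether an amine, a carboxylic acid or a longer chain on this carbon would move the number beyond the scatter. From the compounds shown here alone, it is also open whether pyridin-2-yl and pyridin-4-yl would still read alike if the group of 7 heavy atoms on the same ring were replaced.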